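The source may report more compounds than this note shows. Statements on the series, on what has been measured and on what is new or still open speak of the compounds shown alone.

Measured compounds:

- compound 1, `Cc1cccc2sc(N/C(S)=N/[C@H](C)c3cccc4ccccc34)nc12`: > 100000 nM
- compound 2, `C[C@@H](/N=C(\S)Nc1nc2ccccc2s1)c1cccc2ccccc12`: 18900 nM
- compound 3, `Cc1ccc(N/C(S)=N/[C@H](C)c2cccc3ccccc23)nc1`: 5 nM

All three were tested in a functional assay on RBL-2H3 cells (Rattus norvegicus) for inhibition; a higher number here means a weaker inhibitor, a lower number a stronger inhibitor. For compound 1 the result is a limit, not a number: the limit of > 100000 nM in this assay, at which 1 of the 3 values shown sits. Compound 2 differs from compound 1 in one place, (hydrogen in place of methyl on an aromatic carbon), and this gave an at least 5.2-fold lower number from compound 1 to compound 2 (0.72 log units; beyond the scatter). Compound 3 has a different core from compound 1, and that difference is not broken down here; its value in this assay is far below that of compound 2, the lowest of the two numbers recorded.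

Compound 4, `C[C@@H](/N=C(\S)Nc1ccccn1)c1cccc2ccccc12`, is not yet measured. It differs from compound 3 by hydrogen in place of methyl on an aromatic carbon. Going by the values given here, this is the same kind of change as the one from compound 1 to compound 2, but the place is not the same: in compound 1 the methyl sits on a six-membered aromatic ring of carbon only, part of a fused system of two rings, ortho to a fused ring and meta to a fused ring; in compound 3 it sits on a six-membered aromatic ring with one nitrogen, two atoms from the ring nitrogen and para to a large group. Among the compounds with values here, the only measured step of this kind, an at least 5.2-fold lower number from compound 1 to compound 2 (0.72 log units; beyond the scatter), comes from a compound whose starting value is a limit, so its size is uncertain and it was made on a different core. The expectation for compound 4 is therefore a small step, a 2.0-fold higher number from compound 3 to compound 4 (0.30 log units; within the scatter), staying close to compound 3 at 5 nM. Compound 4 is estimated at 10 nM, with a likely range from 2 nM to 60 nM.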

Compound 4, half-maximal inhibitory concentration: > 100000 nM
Compound 4: only a limit was reported; the forecaster's own chance of this, stated with the estimate: 2%; middle value at least 10000-fold (4.00 log units) away from the limit.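

In this assay, going from the 5-methylpyridin-2-yl group to the pyridin-2-yl group, a swap of one methyl for one hydrogen, gave an at least 20000-fold higher number from compound 3 to compound 4 (4.30 log units; beyond the scatter); compound 4 gives > 100000 nM, which is a limit of the assay and not a number, so this step has a known minimum but no known full size. The same written change therefore does not carry from one core to the other in this series, and the two steps even run in opposite directions: the same change on two cores in this assay, an at least 5.2-fold lower number (0.72 log units; beyond the scatter) from compound 1 to compound 2 and an at least 20000-fold higher number (4.30 log units; beyond the scatter) from compound 3 to compound 4, at least 100000-fold (5.02 log units) apart, beyond the scatter of two such steps This shows that the effect of removing a methyl cannot be transferred from the core of compound 1 to the core of compound 3, but with just two pairs, the methyl in a different place in each and a limit in each, it neither gives the true gap between the steps nor explains it: the limit of > 100000 nM in this assay, at which 2 of the 4 values shown sit.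

The compounds shown leave open whether the low number of compound 3 needs a methyl specifically, or whether a longer chain such as ethyl, or a chlorine atom or a methoxy group, in that same place would also keep it. They also leave open how such groups would behave on the core of compound 1.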